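From fluoro to methoxy: compound 3 to compound 4

This account rests on a few compounds, and the source may have more. Where it says the series, first, only, none or still open, it means among the compounds named here.

Of the compounds shown here, three have so far been measured in an ADME assay on cells (Macrophage, Mus musculus) for cytotoxicity, read by resazurin assay, with a stated time of 3 days; on this read-out higher numbers stand for weaker inhibition and lower numbers for stronger inhibition. Compound 1 `O=C(Nc1cc(C(F)(F)F)cc(C(F)(F)F)c1)c1cc(Br)ccc1O` gives 4900 nM in this assay. Compound 2 `O=C(O)c1cccc(NC(=O)c2cc(Cl)ccc2O)c1` gives in this assay only a limit, > 60000 nM, and not a number (the limit of > 60000 nM in this assay, at which 1 of the 3 values shown sits). Compound 3 `O=C(Nc1ccc(F)cc1)c1cc(Cl)ccc1O` gives 17000 nM in this assay, the higher of the two numbers; compound 1 sits lower, and the gap between the two lies beyond the usual scatter of repeated measurements.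

Compound 4 `COc1ccc(NC(=O)c2cc(Cl)ccc2O)cc1` is not yet measured. It differs from compound 3 by methoxy in place of fluoro on an aromatic carbon, para to a large group. Among the compounds with values here, no pair of measured compounds shows this change, so the expectation rests on compound 3 alone. A change of this kind, small in the count of atoms and adding one hydrogen-bond acceptor, is expected to move the number little, and no step beyond the scatter is expected in either direction.

For compound 4 the expected value in this assay is 20000 nM, with a range from 8000 nM to 50000 nM. The step from compound 3 to compound 4 is thus expected to be a 1.2-fold higher number from compound 3 to compound 4 (0.07 log units; within the scatter), within the scatter.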

Compound 4, half-maximal inhibitory concentration: > 60000 nM
Compound 4 gave a limit, no number (the forecaster's own chance of this, stated with the estimate: 20%); middle value at least 3.0-fold (0.47 log units) from the limit.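

Replacing fluoro with methoxy on this aromatic carbon, para to a large group, is not a silent change, despite its small count of atoms: in this assay it gives an at least 3.5-fold higher number from compound 3 to compound 4 (0.54 log units; beyond the scatter). Within the data shown here, this is the first direct reading of this position, and it shows that the group held there can by itself carry the read-out beyond the scatter on an otherwise unchanged core. Compound 4 gives only a limit, > 60000 nM, and not a number, and this limit is now shared within the series: the limit of > 60000 nM in this assay, at which 2 of the 4 values shown sit.

The compounds shown leave open how large the step really is and why it arises, and whether it belongs to methoxy in particular or would also appear with another group at this place, such as an amine, a hydroxyl or a longer chain like ethoxy. They also leave open whether the same change would have a comparable effect on the core of compound 1, where the groups on the aniline ring and the halogen on the other ring are different.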